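Dichlorophenyl to Methoxyphenyl in an MCF7 Series

A few compounds are considered here, and "the series" means these few. Any claim that something is new, unique, unknown or untested is made for them only; others in the source may bear on it.

- Compound 1 `O=C(CC(c1ccccc1)C(C(=O)Nc1ccccn1)C(=O)Nc1ccccn1)c1ccccc1` gives "not active" (no number reported)
- Compound 2 `O=C(CC(c1ccc([N+](=O)[O-])cc1)C(C(=O)Nc1ccccn1)C(=O)Nc1ccccn1)c1ccccc1` gives "not active" (no number reported)
- Compound 3 `O=C(CC(c1ccc(Cl)cc1Cl)C(C(=O)Nc1ccccn1)C(=O)Nc1ccccn1)c1ccccc1` gives 33400 nM

In a functional assay on MCF7 cells (Homo sapiens) for inhibition, read by MTT assay, with a stated time of 48 h (a lower number here means a stronger inhibitor, a higher number a weaker inhibitor), compound 3 stands alone as the only one of the three with a number, at 33400 nM, while the other two entries carry none. Compound 4 `COc1ccc(C(CC(=O)c2ccccc2)C(C(=O)Nc2ccccn2)C(=O)Nc2ccccn2)cc1` has not yet been measured. It departs from compound 3 in one place, on a saturated chain carbon bound to two saturated chain carbons: 4-methoxyphenyl in place of 2,4-dichlorophenyl on a saturated chain carbon bound to two saturated chain carbons. For the measured compounds named here, no step between two measured numbers is available to guide the comparison. Compound 1 at "not active" (no number reported) and compound 2 at "not active" (no number reported) also lack the 2,4-dichlorophenyl group, so compound 4 is expected to be no stronger than compound 3, and a result without a number remains quite possible. A modest weakening is expected in this assay, an estimated 1.6-fold higher number from compound 3 to compound 4 (0.22 log units; within the scatter). For compound 4 the expected value is 55000 nM, with an estimated range from 20000 nM to 150000 nM.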

Compound 4, half-maximal inhibitory concentration: 48300 nM
Compound 4: middle estimate off by 1.1-fold (0.06 log units), on the high side; the measured number falls inside the stated range.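

In this assay the swap of 2,4-dichlorophenyl for 4-methoxyphenyl on a saturated chain carbon bound to two saturated chain carbons gives a 1.4-fold higher number from compound 3 to compound 4 (0.16 log units; within the scatter) and so leaves the two groups indistinguishable at this position. For the compounds shown here, compound 4 also shows that the 2,4-dichlorophenyl group is not the only group here that goes with a number, while the entries for compound 1 and compound 2 still carry none. No measurement shown offers an explanation for this result.

The compounds shown leave open how a single chlorine or a hydroxyl group on the phenyl ring would read at this carbon. As far as these compounds go, the rest of the shared core stays the same throughout, so the effect of an amine or a carboxylic acid elsewhere on it also remains open.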